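Swapping iodo for trifluoromethyl on a shared core

The source may report more compounds than this note shows. Statements on the series, on what has been measured and on what is new or still open speak of the compounds shown alone.

Of the compounds shown here, two built on a shared core have been tested in a functional assay on L1210 cells (Mus musculus) for antiproliferative activity; a lower number here means a stronger inhibitor, a higher number a weaker inhibitor. Compound 1 `O=c1[nH]c(=O)n([C@H]2C[C@@H]3O[PH](O)(O)OC[C@H]3O2)cc1Br` gives only a limit there, > 1000 ug/mL. Compound 2 `O=c1[nH]c(=O)n([C@H]2C[C@@H]3O[PH](O)(O)OC[C@H]3O2)cc1I` likewise gives only a limit, > 500 ug/mL. The step between them, a step that the two limits leave unreadable from compound 1 to compound 2, cannot be read because the limit of > 1000 ug/mL in this assay, at which 1 of the 2 values shown sits, and the limit of > 500 ug/mL in this assay, at which 1 of the 2 values shown sits, both mark the edge of what the test could measure rather than a number. Compound 3 `O=c1[nH]c(=O)n([C@H]2C[C@@H]3O[PH](O)(O)OC[C@H]3O2)cc1C(F)(F)F` carries trifluoromethyl in place of iodo on an aromatic carbon. Within the data shown here, no measured step here can be read, so none gives a foothold for the size or direction of this change. With compound 2 standing only at a limit, compound 3 is expected to sit near a limit as well, and a step that the limit leaves unreadable from compound 2 to compound 3 is the expected step. The estimate for compound 3 is 1000 ug/mL, expected to fall within a range from 250 ug/mL to 4000 ug/mL.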

Compound 3, concentration for 50% inhibition: 22 ug/mL
Compound 3: middle estimate off by 45-fold (1.66 log units), on the high side; measured number below the stated range.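

On this aromatic carbon, the choice of group matters a great deal in this assay: trifluoromethyl in place of iodo gives an at least 22-fold lower number from compound 2 to compound 3 (1.35 log units; beyond the scatter), and trifluoromethyl in place of bromo gives an at least 45-fold lower number from compound 1 to compound 3 (1.65 log units; beyond the scatter). Both sizes are minimums, and the step between the bromo and iodo compounds cannot be read, because compound 1 gives only a limit: the limit of > 1000 ug/mL in this assay, at which 1 of the 3 values shown sits. Compound 2 also gives only a limit: the limit of > 500 ug/mL in this assay, at which 1 of the 3 values shown sits.

These values do not explain why trifluoromethyl stands apart from bromo and iodo, and three compounds cannot show how far the gain extends. A methyl, a nitrile, an amine or a longer chain such as ethyl at this position would show whether trifluoromethyl is unusual here or whether other groups also give a measurable number.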